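Phenyl to 4-chlorophenyl on compound 3

This account rests on a few compounds, and the source may have more. Where it says the series, first, only, none or still open, it means among the compounds named here.

In a functional assay on B16 cells (Mus musculus) for inhibition, with a stated time of 3 days (on this read-out higher numbers stand for weaker inhibition and lower numbers for stronger inhibition), compound 1 (`O=C(Nc1ccc(O)cc1)c1n[nH]c2ccccc12`) gives 18000 nM, compound 2 (`O=C(c1ccccc1)n1ncc2cc([N+](=O)[O-])c(Br)cc21`) gives 32000 nM and compound 3 (`O=C(c1ccccc1)n1ncc2cc([N+](=O)[O-])ccc21`) gives 51000 nM. Compound 3 shares the high end of these numbers with compound 2, lying within the scatter of it and beyond the scatter of compound 1.

Compound 4 (`O=C(c1ccc(Cl)cc1)n1ncc2cc([N+](=O)[O-])ccc21`) differs from compound 3 in one place, with chloro in place of hydrogen on an aromatic carbon. The chloro sits para to a large group, on the phenyl. Going by the values given here, only one measured step bears on this: a 1.6-fold higher number from compound 2 to compound 3 (0.20 log units; within the scatter). Among the compounds with values here, that step removes bromo from a different aromatic carbon, so it is only a loose guide, and no measured step covers chloro at this place. On that evidence, no step beyond the scatter is expected in this assay, and any direction remains tentative. The expected step is a 1.3-fold lower number from compound 3 to compound 4 (0.11 log units; within the scatter). For compound 4 the estimated value is 40000 nM, with an expected range of 17000 nM to 90000 nM.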

Compound 4, half-maximal inhibitory concentration: 60000 nM
Compound 4: middle estimate off by 1.5-fold (0.18 log units), on the low side; low and high end bracket the measured number.
By their numbers in this assay, from the lowest: compounds 1, 2, 3 and 4 (each within the scatter of the next, the first and the last beyond it).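

In this assay, phenyl to 4-chlorophenyl gives a 1.2-fold higher number from compound 3 to compound 4 (0.07 log units; within the scatter), so chloro at this place, para to a large group, leaves the read-out within the scatter. This is the first step shown on the phenyl itself, and the read-out on this ring proves no more responsive to a single swap than the bromo step, a 1.6-fold higher number from compound 2 to compound 3 (0.20 log units; within the scatter), on a different aromatic carbon. No measurement available here bears on why this change leaves the number within the scatter.

Open, as far as these compounds go, is whether a group other than chloro at this place, such as an amine, a carboxylic acid or a longer chain, would take the number beyond the scatter. Also open, from the compounds shown here alone, is whether chloro elsewhere on the phenyl would behave as it does here.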